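The source may hold more compounds than are shown below. What is called first, only, known or untested is meant among the compounds shown, and "the series" means these compounds.

Measured so far:
compound 1, `CNC(=O)c1cc(Oc2ccc(NC(=O)c3nn(-c4ccc(Br)cc4F)c(=O)cc3C)cc2F)ccn1`, 2830 nM in a functional assay on HepG2 cells (Homo sapiens) for cytotoxicity, read by MTT assay, with a stated time of 72 h; on this read-out higher numbers stand for weaker inhibition and lower numbers for stronger inhibition
compound 2, `Cc1cc(=O)n(-c2ccc(Br)cc2F)nc1C(=O)Nc1ccc(Oc2ncnc3ccsc23)c(F)c1`, 3350 nM
compound 3, `Cc1cc(=O)n(-c2ccccc2C(F)(F)F)nc1C(=O)Nc1ccc(Oc2ncnc3sccc23)c(F)c1`, 14700 nM

Compound 3 gives the highest number of the three; compound 2 sits nearest and compound 1 furthest, both gaps beyond the scatter. Compound 4, `Cc1cc(=O)n(-c2ccc(Br)cc2F)nc1C(=O)Nc1ccc(Oc2ncnc3sccc23)c(F)c1`, differs from compound 3 by 4-bromo-2-fluorophenyl in place of 2-(trifluoromethyl)phenyl on an aromatic nitrogen. Among the compounds with values here, no measured step covers this change. Within the data shown here, the only measured step, a 1.2-fold higher number from compound 1 to compound 2 (0.07 log units; within the scatter), concerns the aryl ether and is within the scatter. Compound 2 carries the same 4-bromo-2-fluorophenyl as compound 4, and its number lies well under that of compound 3. For compound 4 a number nearer compound 2 is therefore expected, a step of a 3.7-fold lower number from compound 3 to compound 4 (0.57 log units; beyond the scatter) downward. The estimate for compound 4 is 4000 nM, between 1800 nM and 9000 nM.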

Compound 4, half-maximal inhibitory concentration: 13800 nM
Beside the measured number, compound 4's estimate is 3.5-fold (0.54 log units) below it; measured number outside the range, above it.
By their numbers in this assay, from the lowest: compounds 1 and 2 (each within the scatter of the next); then compounds 4 and 3 (each within the scatter of the next).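

In this assay, the exchange of 2-(trifluoromethyl)phenyl for 4-bromo-2-fluorophenyl on the aromatic nitrogen gives a 1.1-fold lower number from compound 3 to compound 4 (0.03 log units; within the scatter) and so shows no response at this position in this pair. With 4-bromo-2-fluorophenyl held, the group on the ether oxygen carries the larger differences: a 4.1-fold higher number from compound 2 to compound 4 (0.61 log units; beyond the scatter) arises between two groups of the same composition, and a 4.9-fold higher number from compound 1 to compound 4 (0.69 log units; beyond the scatter) arises with the other ether group. No available evidence bears on the origin of these differences.

From the compounds shown here alone, whether the aromatic nitrogen stays equally unresponsive with other groups on the ether oxygen remains open. Going by these compounds, the effect of an aryl group there carrying an amine or a carboxylic acid also remains open.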